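The compounds below may be only part of what the source reports. "The series", "measured", "known", "first", "only" and "open" are said of these compounds alone.

In an assay on membranes from brain for displacement of a labelled ligand from Sigma non-opioid intracellular receptor 1 (Cavia porcellus), read by scintillation counting, with a stated time of 120 min (on this read-out higher numbers stand for weaker inhibition and lower numbers for stronger inhibition), three compounds sharing one core have been measured. Compound 1 `O=[N+]([O-])c1ccc(-c2scc3c2CCOC32CCN(Cc3ccccc3)CC2)cc1` gives 1.7 nM. Compound 2 `COC1Cc2c(csc2-c2ccc(-c3ccccc3)cc2)C2(CCN(Cc3ccccc3)CC2)O1` gives 30 nM. Compound 3 `COc1ccc(-c2cc3c(s2)C2(CCN(Cc4ccccc4)CC2)OC(OC)C3)cc1` gives 56 nM, the highest of the three numbers; its gap to compound 2 lies within the scatter, whereas compound 1 stands well apart from it, beyond the scatter.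

Compound 4 `COC1Cc2cc(-c3ccc(C(C)=O)cc3)sc2C2(CCN(Cc3ccccc3)CC2)O1` is not yet measured. It differs from compound 3 in one place: acetyl in place of methoxy on an aromatic carbon. Among the compounds with values here, no pair of measured compounds differs by this change alone, so the expectation rests on the spread of the three numbers rather than on a like-for-like step. The account expects compound 4 to come out with a somewhat lower number in this assay than compound 3, the step from a 2.2-fold lower number from compound 3 to compound 4 (0.35 log units; beyond the scatter) being small and close to the edge of the scatter. Compound 4 is therefore estimated at 25 nM, with a range from 6 nM to 100 nM.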

Compound 4, inhibition constant: 59 nM
Compound 4: middle estimate off by 2.4-fold (0.37 log units), on the low side, and the stated range covers the measured number.
By their numbers in this assay, from the lowest: compound 1; then compounds 2, 3 and 4 (each within the scatter of the next).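

At this position, on an aromatic carbon para to a large group, this assay records a 1.1-fold higher number from compound 3 to compound 4 (0.02 log units; within the scatter) for acetyl in place of methoxy. This is the only like-for-like step among the compounds shown, and it shows that the assay does not separate 4-methoxyphenyl from 4-acetylphenyl here, which the spread across the earlier compounds could not show. No measurement offered here bears on why the two groups read alike.

Going by these compounds, whether an amine or a carboxylic acid on the same aromatic carbon would also stay within the scatter of methoxy and acetyl remains open. Also open, on these data alone, is which difference sets compound 1 at 1.7 nM apart, since compound 1 differs from the others in more than one place and no single change can be tied to its number.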